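Urea aryl isomers on the shared core: isoquinoline to quinoline

The source may report more compounds than this note shows. Statements on the series, on what has been measured and on what is new or still open speak of the compounds shown alone.

Measured so far in an assay on CHO cells for antagonist activity at transient receptor potential cation channel subfamily V member 1 (Homo sapiens), read by scintillation counting, with a stated time of 5 min, in the presence of a further agent that is not named here; on this read-out higher numbers stand for an effect only at larger amounts of compound and lower numbers for an effect already at smaller amounts:
- compound 1, `CN(C)C1(Cc2ccccc2)CCN(c2cc(C(F)(F)F)ccc2CNC(=O)Nc2cccc3[nH]c(=O)ccc23)CC1`: 30.6 nM
- compound 2, `CN(C)C1(Cc2ccccc2)CCN(c2cc(C(F)(F)F)ccc2CNC(=O)Nc2ccc3ccncc3c2)CC1`: 56.1 nM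

Among the measured compounds shown here, compound 2 holds the higher of the two numbers in this assay, but its only neighbour is compound 1, and the step of a 1.8-fold higher number from compound 1 to compound 2 (0.26 log units; within the scatter) is within the scatter, so the two cannot be ordered on these data.

Compound 3, `CN(C)C1(Cc2ccccc2)CCN(c2cc(C(F)(F)F)ccc2CNC(=O)Nc2cccc3ncccc23)CC1`, keeps the whole of compound 2 apart from the aryl group on the urea: quinolin-5-yl in place of isoquinolin-7-yl on an amide-type nitrogen. For the measured compounds named here, the two aryl groups hold the same atoms, joined differently, and no measured pair shows this rearrangement. Going by the values given here, the only step known at this nitrogen, a 1.8-fold higher number from compound 1 to compound 2 (0.26 log units; within the scatter), exchanged a different group and stayed within the scatter. With nothing pointing either way, the expectation for compound 3 is a number near that of compound 2, the expected step being a 1.0-fold lower number from compound 2 to compound 3 (0.01 log units; within the scatter), not beyond the scatter.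

Compound 3 is therefore estimated at 55 nM in this assay, with a range from 18 nM to 170 nM.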

Compound 3, half-maximal effective concentration: 32 nM
Compound 3: the middle estimate sits 1.7-fold (0.24 log units) above what was measured, within the range that was stated.
By their numbers in this assay, from the lowest: compounds 1, 3 and 2 (each within the scatter of the next).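

Notes on the urea aryl position: in this assay the change from isoquinolin-7-yl to quinolin-5-yl on the amide-type nitrogen gives a 1.8-fold lower number from compound 2 to compound 3 (0.24 log units; within the scatter) and so cannot be told apart from repeat scatter, which makes this the first view of the same atoms joined differently at this place. The comparison with the oxygen-bearing group of compound 1 gives a 1.0-fold higher number from compound 1 to compound 3 (0.02 log units; within the scatter) and is likewise unresolved, so all three aryl groups now sit within the scatter of one another, and this position has so far tolerated both a rearrangement of the ring atoms and the exchange of a larger group for a smaller one without a readable shift. No supporting measurement on these compounds bears on this result.

Still open, on these data alone, is whether any group at this nitrogen moves the number beyond the scatter, for example a plain phenyl, or a phenyl carrying a carboxylic acid or a primary amine. Also open, as far as these compounds go, is whether further isomers such as quinolin-7-yl or isoquinolin-5-yl would stay within the same narrow band on the shared core.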